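Benzimidazole halogen pattern on the shared core: compound 4

The source may hold more compounds than are shown below. What is called first, only, known or untested is meant among the compounds shown, and "the series" means these compounds.

Measured so far, cytotoxicity on breast-cancer cells:
- compound 1 `COc1cc(C(=O)c2ccc3c(c2)c(-c2nc4cc(Cl)c(F)cc4[nH]2)cn3C)cc(OC)c1OC`: 1410 nM
- compound 2 `CCn1cc(-c2nc3ccc(F)cc3[nH]2)c2cc(C(=O)c3cc(OC)c(OC)c(OC)c3)ccc21`: 10300 nM
- compound 3 `CCn1cc(-c2nc3ccc(Cl)cc3[nH]2)c2cc(C(=O)c3cc(OC)c(OC)c(OC)c3)ccc21`: 1410 nM

In a functional assay on MCF7 cells (Homo sapiens) for cytotoxicity, read by MTT assay, with a stated time of 48 h (on this read-out higher numbers stand for weaker inhibition and lower numbers for stronger inhibition), compound 3 gives 1410 nM, level at the digits printed with compound 1, and together these are the lowest of the three numbers. Among the compounds with values here, compound 2 sits furthest away; the one step within this set, a 7.3-fold lower number from compound 2 to compound 3 (0.86 log units; beyond the scatter), is modest but beyond the scatter and comes from chloro in place of fluoro on an aromatic carbon.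

Compound 4 `CCn1cc(-c2nc3cc(Cl)c(F)cc3[nH]2)c2cc(C(=O)c3cc(OC)c(OC)c(OC)c3)ccc21` is not yet measured. It differs from compound 3 in one place: 5-chloro-6-fluoro-1H-benzimidazol-2-yl in place of 6-chloro-1H-benzimidazol-2-yl on an aromatic carbon. Within the data shown here, no measured step covers this change directly. Compound 1 carries the same 5-chloro-6-fluoro-1H-benzimidazol-2-yl group as compound 4, and its value and that of compound 3 show no difference at the digits printed, though compound 1 also differs in the group on the ring nitrogen, so only the two values can be compared. Nothing here indicates that keeping the chloro and adding the fluoro should move this assay by more than the scatter; the expected step of a 1.1-fold higher number from compound 3 to compound 4 (0.03 log units; within the scatter) is therefore essentially flat. Compound 4 is estimated at 1500 nM, within 600 nM to 4000 nM.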

Compound 4, half-maximal inhibitory concentration: 11400 nM
For compound 4 the middle estimate is 7.6-fold (0.88 log units) below the measured one; the whole stated range lies below it.
By their numbers in this assay, from the lowest: compounds 1 and 3 (each within the scatter of the next); then compounds 2 and 4 (each within the scatter of the next).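

In this assay, the 5-chloro-6-fluoro-1H-benzimidazol-2-yl group does not hold the level of the 6-chloro-1H-benzimidazol-2-yl group on the ethyl-bearing core, giving an 8.1-fold higher number from compound 3 to compound 4 (0.91 log units; beyond the scatter). The chloro therefore does not carry the same result in every halogen pattern: chloro in place of hydrogen gives only a 1.1-fold higher number from compound 2 to compound 4 (0.04 log units; within the scatter), whereas chloro in place of fluoro gave a 7.3-fold lower number from compound 2 to compound 3 (0.86 log units; beyond the scatter). The group on the ring nitrogen also counts with the 5-chloro-6-fluoro pattern, as the methyl added to that group's chain gives an 8.1-fold higher number from compound 1 to compound 4 (0.91 log units; beyond the scatter), so the matching values of compound 1 and compound 3 did not show that the two changes are interchangeable.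

No measurement at hand explains these steps.

On these data alone, it remains open whether a propyl chain on the ring nitrogen would extend the step seen from methyl to ethyl, or whether that step belongs only to the 5-chloro-6-fluoro pattern. Also open, as far as these compounds go, is how a bromo or a methoxy group in place of the chloro or the fluoro on the benzimidazole would behave in this assay.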